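Pyrrolidin-1-yl for thiomorpholin-4-yl: from compound 2 to compound 4

This account rests on a few compounds, and the source may have more. Where it says the series, first, only, none or still open, it means among the compounds named here.

In a functional assay on HeLa cells (Homo sapiens) for cytotoxicity, read by MTT assay, with a stated time of 72 h, tested at 1 uM (a higher number here means more inhibition of growth at the concentration tested, a lower number less inhibition of growth), compound 1 `Cc1ccnc(/C(N)=N/NC(=S)N2CCSCC2)c1` gives 41.1% and compound 3 `Cc1ccnc(/C(N)=N/NC(=S)N2CCN(c3ccccn3)CC2)c1` gives 40.4%. Compound 2 `N/C(=N\NC(=S)N1CCSCC1)c1ccccn1` gives 25.1%, the lowest of the three numbers, both others standing beyond the scatter above it. Among the measured compounds shown here, the one measured step, a number 16 percentage points lower from compound 1 to compound 2 (beyond the scatter), is hydrogen in place of methyl on an aromatic carbon, a modest loss. Compound 4 `N/C(=N\NC(=S)N1CCCC1)c1ccccn1` differs from compound 2 by pyrrolidin-1-yl in place of thiomorpholin-4-yl on a thiocarbonyl carbon. For the measured compounds named here, no measured step alters the group on the thiocarbonyl carbon: the single step concerns a methyl, and compound 3 differs from compound 2 in two places, so it gives no step to read. The step of a number 0.1 percentage points lower from compound 2 to compound 4 (within the scatter) is therefore expected to stay within the scatter. Compound 4 is estimated at 25%, within 8% to 42%.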

Compound 4, percent growth inhibition at one concentration: 24.7%
The estimate for compound 4 lay 0.3 percentage points above the measured number; the range from low to high includes it.
By their numbers in this assay, from the lowest: compounds 4 and 2 (each within the scatter of the next); then compounds 3 and 1 (each within the scatter of the next).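

In this assay, the group on the thiocarbonyl carbon now has a step of its own: a number 0.4 percentage points lower from compound 2 to compound 4 (within the scatter). Pyrrolidin-1-yl, a five-membered ring without the sulfur, therefore cannot be told apart from thiomorpholin-4-yl at this position on the core of compound 2. Nothing available here gives a reason for this result.

On these data alone, it remains open whether an open-chain group such as dimethylamino, or morpholin-4-yl with oxygen in its ring, would also stay level. As far as these compounds go, it also remains open whether pyrrolidin-1-yl behaves alike on the core of compound 1.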